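Dipropylamino to butylamino on the shared core

A few compounds are considered here, and "the series" means these few. Any claim that something is new, unique, unknown or untested is made for them only; others in the source may bear on it.

Compound 1 `CCCN(CCC)Cc1ccc(Cl)c(-c2ccccc2OC)c1` is reported in a functional assay on HEK293 cells for agonist activity at 5-hydroxytryptamine receptor 7 (Homo sapiens), read by cAMP accumulation, with a stated time of 30 min (a lower number here means that less compound is needed, a higher number that more compound is needed for the effect), as "not active" (no number reported), so no single number stands for it. Compound 2 `CCNCc1ccc(Cl)c(-c2ccccc2OC)c1` gives 759 nM; 770 nM (2 entries) in this assay, its two entries lying close together (the several entries of compound 2 in this assay, 759 nM; 770 nM (2 entries)). Compound 3 `CCCCNCc1ccc(Cl)c(-c2ccccc2OC)c1` is not yet measured. It differs from compound 1 by butylamino in place of dipropylamino on a saturated chain carbon bound to an aromatic carbon. Going by the values given here, no step between measured compounds is known, so the size of the move from compound 1 to compound 3 in this assay cannot be read from any pair. The change brings in one hydrogen-bond donor, and compound 2, which carries one as well, shows a measurable value 759 nM; 770 nM (2 entries); the expectation is therefore a move from no reported number toward a value of that order, beyond the scatter. Compound 3 is estimated at 700 nM, with a range from 150 nM to 3000 nM.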

Compound 3, half-maximal effective concentration: "not active" (no number reported)
The entry for compound 3 holds no number, and the estimate cannot be compared.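

Going by these compounds alone, compound 1 and compound 3 both stand without a number in this assay so no step between them can be read. The compounds shown leave open what separates compound 3 from compound 2 (759 nM; 770 nM (2 entries)) and how far the measurable response extends along the amine chain on the shared core.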